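A few compounds are considered here, and "the series" means these few. Any claim that something is new, unique, unknown or untested is made for them only; others in the source may bear on it.

In an assay (Rattus norvegicus) for inhibition of Fatty-acid amide hydrolase 1 (Homo sapiens) (on this read-out lower numbers stand for stronger inhibition and higher numbers for weaker inhibition), compound 3 `O=C(CCCCCCc1ccccc1)c1ncc(-c2ccc([N+](=O)[O-])cc2)o1` gives 50 nM, the second highest of the three numbers: compound 1 `O=C(CCCCCCc1ccccc1)c1ncc(-c2ccccc2F)o1` gives 110 nM and compound 2 `Nc1cccc(-c2cnc(C(=O)CCCCCCc3ccccc3)o2)c1` gives 19 nM. Compound 4 `NS(=O)(=O)c1ccc(-c2cnc(C(=O)CCCCCCc3ccccc3)o2)cc1` differs from compound 3 by sulfamoyl in place of nitro on an aromatic carbon. Going by the values given here, two measured steps bear on this change, both at the same aromatic carbon: a 2.2-fold lower number from compound 1 to compound 3 (0.34 log units; beyond the scatter) and a 2.6-fold higher number from compound 2 to compound 3 (0.42 log units; beyond the scatter). The group on that carbon thus shifts this assay by modest amounts in either direction, and compound 2, carrying the amino group, has the lowest number. A modest lower number is therefore expected for compound 4, as a 1.7-fold lower number from compound 3 to compound 4 (0.22 log units; within the scatter). Compound 4 is estimated at 30 nM, with a range from 12 nM to 90 nM.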

Compound 4, inhibition constant: 10 nM
Compound 4: middle estimate off by 3.0-fold (0.48 log units), on the high side, outside the stated range (below it).
By their numbers in this assay, from the lowest: compounds 4 and 2 (each within the scatter of the next); then compound 3; then compound 1.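

Sulfamoyl in place of nitro gives a 5.0-fold lower number from compound 3 to compound 4 (0.70 log units; beyond the scatter) in this assay, a larger step than either earlier change at this ring position had suggested from compound 3. The low end of the series is therefore not confined to the 3-aminophenyl group, since compound 4 lies within the scatter of compound 2. Nothing shown accounts for the size of this step. From the compounds shown here alone, it remains open whether a carboxylic acid or a methyl sulfone on the same carbon would keep the number this low, and whether the amino group would match sulfamoyl there.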